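From Methoxy to Hydroxy in Compound 3

This account rests on a few compounds, and the source may have more. Where it says the series, first, only, none or still open, it means among the compounds named here.

The compounds measured so far in a functional assay on RL cells (Homo sapiens) for cytotoxicity, with a stated time of 48 h (on this read-out lower numbers stand for stronger inhibition and higher numbers for weaker inhibition), are:
Compound 1 `COc1cc(OC)c(C(=O)/C=C/c2ccccc2SC)c(OC)c1` gives 8300 nM
Compound 2 `COc1cc(OC)c(C(=O)/C=C/c2ccc(Br)cc2)c(OC)c1` gives 8300 nM

Within the data shown here, compound 1 stands level with compound 2, its only measured neighbour, and the one step available is no change at the digits printed from compound 1 to compound 2 (within the scatter) within the scatter. That step puts 4-bromophenyl in place of 2-(methylsulfanyl)phenyl and leaves the methoxy groups of the shared core untouched.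

Compound 3 `COc1cc(O)c(C(=O)/C=C/c2ccccc2SC)c(OC)c1` departs from compound 1 in a different place, and the difference is hydrogen in place of methyl on an oxygen on an aromatic ring in the form of methoxy to hydroxy, with hydrogen in place of methyl on an oxygen on an aromatic ring. Among the measured compounds shown here, no measured step covers this change, so its size in this assay cannot be read directly from the data. For the measured compounds named here, the flat step above shows only that one exchange elsewhere in the molecule left the number where it was. A modest shift towards a lower number is therefore expected, though no shift beyond the scatter remains possible. The estimated step is a 1.7-fold lower number from compound 1 to compound 3 (0.22 log units; within the scatter) and it carries wide uncertainty. For compound 3 the expected value is 5000 nM with an estimated range from 1800 nM to 14000 nM in this read-out.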

Compound 3, half-maximal inhibitory concentration: 8900 nM
Compound 3: middle estimate off by 1.8-fold (0.25 log units), on the low side, and the stated range covers the measured number.
By their numbers in this assay, from the lowest: compounds 1, 2 and 3 (each within the scatter of the next).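

In this assay, hydrogen in place of methyl on an oxygen on an aromatic ring gives a 1.1-fold higher number from compound 1 to compound 3 (0.03 log units; within the scatter) and so leaves the read-out within the scatter. The earlier pair had changed only 2-(methylsulfanyl)phenyl to 4-bromophenyl and so said nothing about this oxygen, whereas this step shows that, with 2-(methylsulfanyl)phenyl in place, the methyl on it can be lost with no change beyond the scatter. No evidence at hand accounts for this result.

The compounds shown leave open whether the same exchange would also stay within the scatter with 4-bromophenyl in the molecule, and whether the remaining methoxy groups of the shared core would behave as this one does. They also leave open what a different group at this place would do, such as an amine in place of the hydroxy, or a longer chain like ethoxy or one ending in a carboxylic acid, since a single exchange of methyl for hydrogen cannot show how far the read-out stays flat here.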